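Opening the sulfur ring of compound 1

This account rests on a few compounds, and the source may have more. Where it says the series, first, only, none or still open, it means among the compounds named here.

Compound 1 `O=C(CCCCC1CCSS1)Nc1ccc([N+](=O)[O-])c(C(F)(F)F)c1` has no number to stand on: in a functional assay on Bel-7402 cells (Homo sapiens) for inhibition, read by MTT assay, with a stated time of 24 h, tested at 10 ug/mL (a higher number here means more inhibition of growth at the concentration tested, a lower number less inhibition of growth), compound 1 is recorded as "not active" (no number reported) with no figure given. Compound 3 `O=C(CCCCC(S)CCS)Nc1ccc([N+](=O)[O-])c(C(F)(F)F)c1` keeps the core of compound 1 and shows a group of 5 heavy atoms (3 carbon, 2 sulfur; no ring) in place of a group of 5 heavy atoms (3 carbon, 2 sulfur; one five-membered non-aromatic ring with 2 hetero atoms), on a saturated chain carbon, four bonds along the chain from a carbonyl carbon on a saturated chain carbon, four bonds along the chain from a carbonyl carbon. The entering 1,3-disulfanylpropyl group also occurs in compound 2 `O=C(CCCCC(S)CCS)Nc1ccc(Cl)cc1`, which differs elsewhere and gives 1.16% in that test. In this assay a slight rise at most is therefore expected, none beyond the usual scatter. For compound 3 the estimated inhibition is 5% with 0% to 22% as the expected range.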

Compound 3, percent growth inhibition at one concentration: "not active" (no number reported)
The entry for compound 3 holds no number, and the estimate cannot be compared.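

Neither compound 1 nor compound 3 carries a number in this assay and no step can be read between them. On these data alone, what the 1,3-disulfanylpropyl group does to growth inhibition, compared with the ring it replaces, stays open. No other data bear on this result.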